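A few compounds are considered here, and "the series" means these few. Any claim that something is new, unique, unknown or untested is made for them only; others in the source may bear on it.

Series notes. Compound 1 `CCC[C@H]1C[C@@H](OC)C/C(C)=C\[C@@H]2C[C@@H](OC(=O)c3ccccc3CCc3coc(/C=C\CNC(=O)OC)n3)C[C@H](CC(=O)O1)O2` and compound 2 `CCC[C@H]1C[C@@H](OC)C/C(C)=C\[C@@H]2C[C@@H](OC(=O)/C=C\CCc3coc(/C=C\CNC(=O)OC)n3)C[C@H](CC(=O)O1)O2` share one macrocyclic scaffold and differ in the ester side chain. In a functional assay on PANC-1 cells (Homo sapiens) for antiproliferative activity, read by WST assay, with a stated time of 96 h (a higher number here means a weaker inhibitor, a lower number a stronger inhibitor), compound 1 gives 75 nM, while in this assay compound 2 gives 2.4 nM, the lowest number of the two, with compound 1 standing higher by a margin beyond the scatter. Compound 3 `C/C=C\c1nc(CC/C=C\C(=O)O[C@H]2C[C@@H]3CC(=O)O[C@@H](CCC)C[C@@H](OC)C/C(C)=C\[C@H](C2)O3)co1` differs from compound 2 by hydrogen in place of (methoxycarbonyl)amino on a saturated chain carbon bound to a double-bonded chain carbon. Going by the values given here, no measured pair shows this change; the step of an 8.3-fold higher number from compound 2 to compound 3 (0.92 log units; beyond the scatter) is expected to be a moderate loss, toward a higher number, beyond the scatter. Compound 3 is expected to give 20 nM in this assay, within 5 nM to 100 nM.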

Compound 3, half-maximal inhibitory concentration: 440 nM
Compound 3: the middle estimate sits 22-fold (1.34 log units) below what was measured, and the stated range ends below it.
By their numbers in this assay, from the lowest: compound 2; then compound 1; then compound 3.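

Replacing (methoxycarbonyl)amino with hydrogen on a saturated chain carbon bound to a double-bonded chain carbon gives a 180-fold higher number from compound 2 to compound 3 (2.26 log units; beyond the scatter) in this assay. This position is therefore far from indifferent to what it carries, and the prop-1-en-1-yl end of compound 3 does not retain the activity of compound 2. Nothing at hand accounts for the size of this loss.

From the compounds shown here alone, whether the whole group is needed stays open: a free amine or a hydroxyl at this carbon would test that. Going by these compounds, the same change on the ester side chain of compound 1 also remains open.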